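The source may hold more compounds than are shown below. What is called first, only, known or untested is meant among the compounds shown, and "the series" means these compounds.

Measured so far in a functional assay on the whole organism (strain CD-1) with Mus musculus as the target, in the maximal electroshock model, with a stated time of 0.5 h; a lower number here means that less compound is needed, a higher number that more compound is needed for the effect:
compound 1 `CC1(c2ccccc2)CC(=O)N(CC(=O)N2CCN(c3ccccc3F)CC2)C1=O` gives 100 mg/kg
compound 2 `Cc1cccc(N2CCN(C(=O)CN3C(=O)CC(C)(c4ccccc4)C3=O)CC2)c1` gives 100 mg/kg
compound 3 `CC1(c2ccccc2)CC(=O)N(CC(=O)N2CCN(c3cccc(Cl)c3)CC2)C1=O` gives 300 mg/kg

Compound 3 holds the highest of the three numbers. Its nearest neighbour is compound 1, set apart by a 3.0-fold higher number from compound 1 to compound 3 (0.48 log units; beyond the scatter); compound 2 lies at the same distance, by a 3.0-fold higher number from compound 2 to compound 3 (0.48 log units; beyond the scatter). Compounds 1 and 2 are not separated beyond the scatter, as no change at the digits printed from compound 1 to compound 2 (within the scatter) shows.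

Compound 4 `COc1cccc(N2CCN(C(=O)CN3C(=O)CC(C)(c4ccccc4)C3=O)CC2)c1` has not yet been measured. It differs from compound 3 thus: methoxy in place of chloro on an aromatic carbon. For the measured compounds named here, the only measured step at this aromatic carbon is the one from compound 2 to compound 3, where chloro took the place of methyl and the number rose by a 3.0-fold higher number from compound 2 to compound 3 (0.48 log units; beyond the scatter). The step from compound 1 to compound 3, a 3.0-fold higher number from compound 1 to compound 3 (0.48 log units; beyond the scatter), points the same way for chloro. Going by the values given here, no measured compound carries methoxy, so its effect is not known from this series; the two groups that have been tried at this carbon differ by a modest step, and methoxy is expected to land within that span.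

Compound 4 is therefore expected to give about 150 mg/kg, in the range 70 mg/kg to 300 mg/kg. The expected step is a 2.0-fold lower number from compound 3 to compound 4 (0.30 log units; within the scatter).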

Compound 4, minimum effective dose: "not active" (no number reported)
Compound 4: no number reported; the estimate stays without a comparison.
By their numbers in this assay, from the lowest: compounds 1 and 2 (each within the scatter of the next); then compound 3.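

In this assay, for the compounds shown here, compound 4 is recorded as "not active" without a number, so no step to compound 4 from compound 1, compound 2 or compound 3 can be read. Nothing available bears on a cause for this result. The compounds shown leave open how 3-methoxyphenyl compares numerically with 3-chlorophenyl.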